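Hydroxy to sulfo at the chain terminus of compound 3

The compounds below may be only part of what the source reports. "The series", "measured", "known", "first", "only" and "open" are said of these compounds alone.

Measured compounds:
- compound 1 `COc1cc(N)c(Cl)cc1C(=O)NC1CCNCC1`: 398 nM
- compound 2 `CC(C)n1c(=O)n(C(=O)NC2CCNCC2)c2ccccc21`: 316 nM
- compound 3 `COc1cc(N)c(Cl)cc1C(=O)NC1CCN(CCCCCCCCO)CC1`: 15.9 nM

In a functional assay on HEK293 cells for agonist activity at 5-hydroxytryptamine receptor 4 (Homo sapiens), read by cAMP accumulation (a lower number here means that less compound is needed, a higher number that more compound is needed for the effect), compound 3 stands lowest of the three numbers; compound 2 is nearest and compound 1 furthest, both beyond the scatter. For the measured compounds named here, the only one-place step recorded is a 25-fold lower number from compound 1 to compound 3 (1.40 log units; beyond the scatter), which shows what the 8-hydroxyoctyl chain on the ring amine nitrogen does relative to compound 1.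

Compound 4 `COc1cc(N)c(Cl)cc1C(=O)NC1CCN(CCCCCCCCS(=O)(=O)O)CC1` differs from compound 3 by sulfo in place of hydroxy on a saturated chain carbon, eight bonds along the chain from an amine nitrogen in a ring. Going by the values given here, no measured pair changes the group at the end of that chain, so nothing recorded bears directly on the step; the step from compound 1 to compound 3 only shows that the chain with its terminal hydroxy is where the gain sits. Among the compounds with values here, with the chain kept and only its end group exchanged, a moderate shift in this assay is expected rather than a return toward compound 1, with a wide range because no comparable step is available. Compound 4 is therefore estimated at 32 nM with a range of 8 nM to 130 nM, meaning an expected step of a 2.0-fold higher number from compound 3 to compound 4 (0.30 log units; within the scatter).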

Compound 4, half-maximal effective concentration: 1000 nM
Compound 4: middle estimate off by 31-fold (1.49 log units), on the low side, outside the stated range (above it).
By their numbers in this assay, from the lowest: compound 3; then compounds 2 and 1 (each within the scatter of the next); then compound 4.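

In this assay the end of the chain proves highly sensitive to this exchange: sulfo in place of hydroxy gives a 63-fold higher number from compound 3 to compound 4 (1.80 log units; beyond the scatter) and so removes the gain seen in a 25-fold lower number from compound 1 to compound 3 (1.40 log units; beyond the scatter) even though the chain itself stays. The chain alone therefore does not carry that gain, since compound 4 gives 1000 nM and its parent without the chain, compound 1, gives 398 nM in the same assay. No measurement on hand accounts for the size of this step.

The compounds shown leave open whether the drop is particular to sulfo or would also follow from a carboxylic acid, an amine or a methoxy group at the chain end. They also leave open how a shorter or longer chain ending in hydroxy would read.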